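The compounds below may be only part of what the source reports. "The series", "measured", "known", "first", "only" and "open" are said of these compounds alone.

Of the compounds shown here, two have so far been measured in an assay on HEK293 cells for positive allosteric modulation of metabotropic glutamate receptor 3 (Rattus norvegicus), read by thallium flux, with a stated time of 2.5 min; on this read-out higher numbers stand for larger maximal responses and lower numbers for smaller maximal responses. Compound 1, `Cc1c(OCCCCOc2ccc(C(=O)O)cc2)ccc(C(=O)CC2CCCC2)c1O`, gives 26.7% in this assay. Compound 2, `CCCC(=O)c1ccc(OCCCCOc2cc(C(=O)O)ccc2OC)c(C)c1O`, gives 64.2% in this assay. Compound 1 therefore stands lowest of the two numbers, and the nearest, compound 2, lies higher by a margin beyond the usual scatter. Compound 2 differs from compound 1 in several places at once, so these two values show only the gap itself.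

Compound 3, `Cc1c(OCCCCOc2cccc(C(=O)O)c2)ccc(C(=O)CC2CCCC2)c1O`, has not yet been measured. It differs from compound 1 by 3-carboxyphenyl in place of 4-carboxyphenyl on an oxygen on a saturated carbon. Within the data shown here, no step between two measured compounds follows this change, so its direction is open; a moderate shift either way, or none beyond the scatter, is possible. Compound 3 is expected to give about 35% in this assay, within 12% to 65%. The expected step is a number 8.3 percentage points higher from compound 1 to compound 3 (within the scatter).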

Compound 3, largest response reached (reported as percent of maximum), in percent of the reference or control that the assay uses: 92.9%
For compound 3 the middle estimate is 57.9 percentage points below the measured one, and the stated range ends below it.
By their numbers in this assay, from the lowest: compound 1; then compound 2; then compound 3.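

Moving the carboxylic acid to another place on the ring, with the rest of the molecule unchanged, has a large effect in this assay: 3-carboxyphenyl in place of 4-carboxyphenyl on an oxygen on a saturated carbon gives a number 66.2 percentage points higher from compound 1 to compound 3 (beyond the scatter) in the maximal response. Among these compounds, the two groups have the same atoms, joined differently, so this is the first comparison here in which a single change can be read. At this position, the maximal response depends strongly on where the acid sits on the ring, although nothing available explains why.

Going by these compounds, this is one pair on one core, so whether the same change would have a similar effect with a different ketone side chain stays open. Also open, on these data alone, is how the response would change with a tetrazole or a primary amide in place of the carboxylic acid, or with a shorter chain joining the two rings.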